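The compounds below may be only part of what the source reports. "The series", "measured", "known", "first", "only" and "open" are said of these compounds alone.

Compound 3, `CCCCC(CC(=O)O[C@H](CC=C(C)C)C1=CC(=O)c2c(O)ccc(O)c2C1=O)OC(C)=O`, in a functional assay on HeLa cells (Homo sapiens) for cytotoxicity, read by MTT assay (on this read-out higher numbers stand for weaker inhibition and lower numbers for stronger inhibition), gives 73500 nM. Compound 2, `CC(C)=CC[C@@H](OC(=O)C1CCOC1)C1=CC(=O)c2c(O)ccc(O)c2C1=O`, gives 73500 nM in this assay, and the step of no change at the digits printed from compound 2 to compound 3 (within the scatter) shows the two standing level. Compound 1, `CC(C)=CC[C@@H](OC(=O)c1ccoc1)C1=CC(=O)c2c(O)ccc(O)c2C1=O`, reaches only a limit of the assay, > 100000 nM. Going by the values given here, the step of an at least 1.3-fold lower number from compound 1 to compound 3 (0.13 log units; that floor lies within the scatter) therefore has a floor that lies within the scatter, so it establishes no change either; the one value sitting at that limit is the limit of > 100000 nM in this assay, at which 1 of the 3 values shown sits.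

Compound 4, `CC(C)=CC[C@@H](OC(=O)CC(O)c1ccccc1)C1=CC(=O)c2c(O)ccc(O)c2C1=O`, differs from compound 3 in one place: hydroxy(phenyl)methyl in place of 1-acetoxypentyl on a saturated chain carbon bound to a carbonyl carbon. The measured steps that bear on this change, no change at the digits printed from compound 2 to compound 3 (within the scatter) and an at least 1.3-fold lower number from compound 1 to compound 3 (0.13 log units; that floor lies within the scatter), both exchange the group on the carbonyl carbon and neither shows a shift beyond the scatter. In this assay, compound 4 is thus expected to show no step beyond the scatter in either direction, and the expected step of a 1.1-fold lower number from compound 3 to compound 4 (0.02 log units; within the scatter) reflects this. Compound 4 is estimated at 70000 nM, with a range from 30000 nM to 150000 nM.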

Compound 4, half-maximal inhibitory concentration: 44500 nM
Compound 4: the middle estimate sits 1.6-fold (0.20 log units) above what was measured, within the range that was stated.
By their numbers in this assay, from the lowest: compounds 4, 2 and 3 (each within the scatter of the next). At a limit, above all of these: compound 1.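

In this assay, hydroxy(phenyl)methyl in place of 1-acetoxypentyl on a saturated chain carbon bound to a carbonyl carbon brings in an aromatic ring and a hydroxy group, yet the result is only a 1.7-fold lower number from compound 3 to compound 4 (0.22 log units; within the scatter). Going by these compounds alone, measured against the other two esters, compound 4 gives a 1.7-fold lower number from compound 2 to compound 4 (0.22 log units; within the scatter) and an at least 2.2-fold lower number from compound 1 to compound 4 (0.35 log units; beyond the scatter), the first step in this set printed as beyond the scatter. Compound 1 stands at a limit, so that step gives a floor and not a measured size: the limit of > 100000 nM in this assay, at which 1 of the 4 values shown sits.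

The aromatic ring and the hydroxy group enter together, so the compounds shown cannot separate what each contributes. On these data alone, whether an amine, a carboxylic acid or a longer chain at this place would move the number remains open.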